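This account rests on a few compounds, and the source may have more. Where it says the series, first, only, none or still open, it means among the compounds named here.

Going by the values given here, compound 3 (`Nc1nc(OCC2CCC2)c2[nH]cnc2n1`) is one of three compounds measured in an assay on HT-29 cells with Methylated-DNA--protein-cysteine methyltransferase (Homo sapiens) as the target; a higher number here means a weaker inhibitor, a lower number a stronger inhibitor. In this assay compound 3 gives only a limit, > 1000000 nM. Compound 1 (`CC/C=C\CCOc1[nH]c(N)nc2ncnc1-2`) likewise gives only a limit, > 1000000 nM. Compound 2 (`Nc1nc(OCC2CC=CCC2)c2[nH]cnc2n1`) also gives only a limit, > 1000000 nM. The step that the two limits leave unreadable from compound 2 to compound 3 cannot be read because both values sit at the limit of > 1000000 nM in this assay, at which 3 of the 3 values shown sit. Compound 4 (`CC(C)C(=O)COc1nc(N)nc2nc[nH]c12`) differs from compound 3 by isopropylcarbonyl in place of cyclobutyl on a saturated chain carbon bound to an oxygen on an aromatic ring. Among the compounds with values here, the one measured step bears on this change only in that it is unreadable, so no size in this assay can be read from it. The writer therefore expects compound 4 to remain at the limit, an estimated step of a number no higher from compound 3 to compound 4 (the limit leaves the size open). The estimate for compound 4 is 1000000 nM, with a range from 300000 nM to 3000000 nM.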

Compound 4, half-maximal inhibitory concentration: > 1000000 nM
Compound 4 was reported as a limit; the forecaster's own chance of this, stated with the estimate: 85%; the middle value lies on the limit itself.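

Going by these compounds alone, no step from compound 3 to compound 4, or from compound 2 to compound 4, can be read, because each pair consists of two limits: the limit of > 1000000 nM in this assay, at which 4 of the 4 values shown sit. The compounds shown leave open whether any group on that chain carbon gives a readable value in this assay at all.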